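This account rests on a few compounds, and the source may have more. Where it says the series, first, only, none or still open, it means among the compounds named here.

Compound 1 `CCCCCCCc1cc2cn(COCCO)c(=O)nc2o1`: in a functional assay on HEL cells (Homo sapiens), read by microscopy (on this read-out lower numbers stand for higher toxicity in this test and higher numbers for lower toxicity in this test), compound 1 gives 400000 nM.
Compound 2 `CCCCC#Cc1cc2cn(COCCO)c(=O)nc2o1`: compound 2 gives > 100000 nM, which is a limit of the assay.
Compound 3 `CCCCCc1cc2cn(COCCO)c(=O)nc2o1`: compound 3 gives > 400000 nM, again only a limit.

Compound 3 thus stands at a limit with no number of its own, and one further value shown, that of compound 2, is also a limit (the limit of > 100000 nM in this assay, at which 1 of the 3 values shown sits, (the limit of > 400000 nM in this assay, at which 1 of the 3 values shown sits)). Compound 4 `CCCCCCc1cc2cn(COCCO)c(=O)nc2o1` differs from compound 3 by methyl in place of hydrogen on a saturated chain carbon, five bonds along the chain from an aromatic carbon. The step that bears on this change is a number no lower from compound 1 to compound 3 (the limit leaves the size open), cut at the same place, whose size the limit leaves open; the other two steps, a step that the limit leaves unreadable from compound 1 to compound 2 and a step that the two limits leave unreadable from compound 2 to compound 3, are likewise unreadable. Compound 4 is therefore expected to remain close to the limit, with a step of a number no higher from compound 3 to compound 4 (the limit leaves the size open) no larger than the scatter. Compound 4 is estimated at 400000 nM, between 200000 nM and 800000 nM.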

Compound 4, minimum cytotoxic concentration: >= 400000 nM
Compound 4 was reported as a limit (the forecaster's own chance of this, stated with the estimate: 60%); the middle value lies on the limit itself.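

In this assay compound 4 gives only a limit of the assay, with no number of its own: the limit of >= 400000 nM in this assay, at which 1 of the 4 values shown sits. Shortening heptyl to hexyl gives a number no lower from compound 1 to compound 4 (the limit leaves the size open), so this change shows a direction but no size. The steps from compound 2 and compound 3 to compound 4 cannot be read.

The compounds shown leave open where a true value would fall for the hexyl and pentyl chains. They also leave open how a longer chain, such as octyl or decyl, or an amine at the chain end, would read in this assay.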